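Acylating the ring amine nitrogen of compound 2

The source may hold more compounds than are shown below. What is called first, only, known or untested is meant among the compounds shown, and "the series" means these compounds.

In a functional assay on NCI-H1975 cells (Homo sapiens) for cytotoxicity, read by MTT assay, with a stated time of 72 h (on this read-out lower numbers stand for stronger inhibition and higher numbers for weaker inhibition), compound 1 (`COc1ccc(/C=C2\CNC/C(=C\c3ccc(OC)c(OC)c3)C2=O)cc1OC`) gives 10300 nM and compound 3 (`CCN1C/C(=C\c2ccc(OC)c(OC)c2)C(=O)/C(=C/c2ccc(OC)c(OC)c2)C1`) gives 8500 nM in the same range, while compound 2 (`COc1cc(/C=C2\CNC/C(=C\c3cc(OC)c(OC)c(OC)c3)C2=O)cc(OC)c1OC`) gives 4000 nM as the lowest of the three numbers. Its gaps to the other two lie beyond the scatter, but only narrowly.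

Compound 4 (`COc1cc(/C=C2\CN(C(=O)CCC(=O)O)C/C(=C\c3cc(OC)c(OC)c(OC)c3)C2=O)cc(OC)c1OC`) comes from compound 2 through a single change ((2-carboxyethyl)carbonyl in place of hydrogen on an amine nitrogen in a ring), namely (2-carboxyethyl)carbonyl in place of hydrogen on an amine nitrogen in a ring.

For the measured compounds named here, only one measured step bears on this nitrogen (a 1.2-fold lower number from compound 1 to compound 3 (0.08 log units; within the scatter)), and it stays within the scatter. That step is weak guidance for two reasons. It brings in ethyl rather than an acyl group, and it was measured on the core of compound 1 rather than that of compound 2. Going by the values given here, no measured compound carries a carbonyl group on this nitrogen, so the data fix no direction for the change.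

The working expectation is therefore no shift beyond the scatter in this assay, with wide margins on both sides. The estimated step is a 1.3-fold higher number from compound 2 to compound 4 (0.10 log units; within the scatter) (a central guess only). For compound 4 the estimated value is 5000 nM (expected range 1800 nM to 14000 nM).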

Compound 4, half-maximal inhibitory concentration: > 60000 nM
Compound 4: no number, only a limit; the forecaster's own chance of this, stated with the estimate: 10%; at least 12-fold (1.07 log units) between middle value and limit.
By their numbers in this assay, from the lowest: compound 2; then compounds 3 and 1 (each within the scatter of the next). At a limit, above all of these: compound 4.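

For the compounds shown here, this nitrogen is not indifferent to what it carries: in this assay the (2-carboxyethyl)carbonyl change gives an at least 15-fold higher number from compound 2 to compound 4 (1.17 log units; beyond the scatter), while the only earlier step on this nitrogen was a 1.2-fold lower number from compound 1 to compound 3 (0.08 log units; within the scatter). Compound 4 reads > 60000 nM in this assay, which is a limit and not a number, so the step has a lower bound but no measured size: the limit of > 60000 nM in this assay, at which 1 of the 4 values shown sits. The two steps differ in both the entering group and the core, ethyl on the core of compound 1 and (2-carboxyethyl)carbonyl on the core of compound 2, so the small ethyl step says nothing general about substitution on this nitrogen.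

The compounds shown do not settle whether the step belongs to the carbonyl on the nitrogen or to the carboxylic acid the chain carries. An acetyl group or the methyl ester of the same chain on this nitrogen would separate the two, and a longer chain with a carboxylic acid, or with an amine in its place, would show how far the step depends on that group.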